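The source may report more compounds than this note shows. Statements on the series, on what has been measured and on what is new or still open speak of the compounds shown alone.

Four compounds share one core and differ only in the group attached to the carbonyl carbon of the amide. Compound 1 `CC(C)C[C@H](N)c1cc(C(F)(F)F)ccc1N1CCN(C(=O)C(C)Cc2ccc(Cl)c(Cl)c2)CC1` gives in an assay on HEK293 cells for displacement of a labelled ligand from Melanocortin receptor 4 (Homo sapiens) (on this read-out lower numbers stand for stronger inhibition and higher numbers for weaker inhibition), 120 nM; 1600 nM (2 entries), two entries that spread widely (the several entries of compound 1 in this assay, 120 nM; 1600 nM (2 entries)). Compound 2 `COc1cc(CC(C)C(=O)N2CCN(c3ccc(C(F)(F)F)cc3[C@@H](N)CC(C)C)CC2)ccc1Cl` gives in this assay 230 nM. Compound 3 `CC(C)C[C@H](N)c1cc(C(F)(F)F)ccc1N1CCN(C(=O)CCC(N)=O)CC1` carries a 2-carbamoylethyl group where compound 2 has 1-(4-chloro-3-methoxybenzyl)ethyl, and in this assay compound 3 gives > 10000 nM, which is a limit of the assay rather than a number. So compound 3 stands at the weak end of everything measured here, with no exact value. The step of an at least 43-fold higher number from compound 2 to compound 3 (1.63 log units; beyond the scatter) was large, and its full size is hidden because of the limit of > 10000 nM in this assay, at which 1 of the 3 values shown sits.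

Compound 4 `Cc1ccc(OCC(=O)N2CCN(c3ccc(C(F)(F)F)cc3[C@@H](N)CC(C)C)CC2)c(C)c1` changes compound 3 in one place: 2,4-dimethylphenoxy in place of carbamoylmethyl on a saturated chain carbon bound to a carbonyl carbon. Only the measured step just described bears on this change, and it ran in the opposite sense, from an aromatic-bearing group to a small amide chain. Going back from a small amide chain to a group with an aromatic ring, the step for compound 4 is expected to be large and toward a lower number, an at least 16-fold lower number from compound 3 to compound 4 (1.22 log units; beyond the scatter). Compound 4 is therefore estimated at about 600 nM, with a likely range from 100 nM to 5000 nM.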

Compound 4, inhibition constant: 4000 nM
Compound 4: middle estimate off by 6.7-fold (0.82 log units), on the low side; the range from low to high includes it.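

Placing an aromatic ring on this saturated chain carbon does lower the number, and the result gives this change a direction of its own, as an at least 2.5-fold lower number from compound 3 to compound 4 (0.39 log units; beyond the scatter) shows. The size of that step remains only a bound because compound 3 rests on a limit of the assay, not on a number: the limit of > 10000 nM in this assay, at which 1 of the 4 values shown sits. Having an aromatic ring is still not enough to reach the level of the earlier ring-bearing amide, since the comparison with compound 2 gives a 17-fold higher number from compound 2 to compound 4 (1.24 log units; beyond the scatter), so the large loss seen with the small amide chain of compound 3 cannot be read as a matter of the ring alone.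

The swap between compound 2 and compound 4 changes several things at once, including the ether oxygen in the chain, the methyl groups in place of chlorine and methoxy on the ring, and the branching methyl, so the compounds shown do not say which of these accounts for the gap. A plain phenoxy group, a chlorophenoxy group or an unsubstituted benzyl group on the same chain would separate these features, and an amine or a carboxylic acid in place of the carbamoyl end remains an open case as well.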